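Aryl swap from compound 3 to compound 4

A few compounds are considered here, and "the series" means these few. Any claim that something is new, unique, unknown or untested is made for them only; others in the source may bear on it.

In a physicochemical assay for solubility, in phosphate buffer, measured as kinetic solubility, at pH 7.4 (on this read-out lower numbers stand for lower solubility and higher numbers for higher solubility), compound 1 `Cc1ccc(C)c(-c2nc(CN3CCC(C(=O)NCCCN4C[C@H](C)C[C@H](C)C4)CC3)c(C)o2)c1` gives 56.1 ug/mL. Compound 2 `Cc1oc(-c2c(F)cccc2F)nc1CN1CCC(C(=O)NCCCN2C[C@H](C)C[C@H](C)C2)CC1` reads > 72 ug/mL, which is a limit. Compound 3 `COc1cccc(F)c1-c1nc(CN2CCC(C(=O)NCCCN3C[C@H](C)C[C@H](C)C3)CC2)c(C)o1` reads > 74 ug/mL, also a limit, so it has no exact number. Compound 4 `Cc1ccc(-c2nc(CN3CCC(C(=O)NCCCN4C[C@H](C)C[C@H](C)C4)CC3)c(C)o2)c(C)c1` carries 2,4-dimethylphenyl in place of 2-fluoro-6-methoxyphenyl on an aromatic carbon. Within the data shown here, two measured steps bear on this change: an at least 1.2-fold higher number from compound 1 to compound 2 (0.10 log units; that floor lies within the scatter) and an at least 1.3-fold higher number from compound 1 to compound 3 (0.12 log units; that floor lies within the scatter). The third, a step that the two limits leave unreadable from compound 2 to compound 3, gives no size. Among the measured compounds shown here, the expectation is anchored by compound 1, the only measured dimethylphenyl compound, which gives 56.1 ug/mL. The estimated step is an at least 1.3-fold lower number from compound 3 to compound 4 (0.12 log units; that floor lies within the scatter), expected toward a lower number and modest in size. For compound 4 the estimated value is 55 ug/mL, with an expected range from 30 ug/mL to 85 ug/mL.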

Compound 4, solubility: > 71 ug/mL
Compound 4 ended at the assay's limit (the forecaster's own chance of this, stated with the estimate: 15%); middle value at least 1.2-fold (0.11 log units) from the limit.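

In this assay, compound 4 gives a limit and not a number: the limit of > 71 ug/mL in this assay, at which 1 of the 4 values shown sits.
The move of one methyl group around the aryl ring gives an at least 1.2-fold higher number from compound 1 to compound 4 (0.10 log units; that floor lies within the scatter), so the two dimethylphenyl isomers cannot be told apart here. A carbon-only aryl group thus also ends at a limit, as the fluorinated aryl groups of compound 2 and compound 3 do, and the steps among these three compounds cannot be read.

As far as these compounds go, how far these three compounds lie past their limits stays open. So does whether a trifluoromethyl or chloro group on this aryl ring would give an exact value.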